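A few compounds are considered here, and "the series" means these few. Any claim that something is new, unique, unknown or untested is made for them only; others in the source may bear on it.

Measured in an ADME assay on MRC5 cells (Homo sapiens) for cytotoxicity, read by resazurin assay, with a stated time of 72 h; on this read-out lower numbers stand for stronger inhibition and higher numbers for weaker inhibition:
Compound 1 `O=[N+]([O-])c1cn2c(n1)OC(COc1ccc(-c3ccc(F)nc3)cc1)CC2`: > 64000 nM
Compound 2 `O=[N+]([O-])c1cn2c(n1)OC(COc1ccc(-c3ccc(OC(F)(F)F)cc3)cn1)CC2`: > 64000 nM

Compound 1 gives > 64000 nM, which is a limit of the assay and not a number. Compound 2 gives > 64000 nM, which is also a limit and not a number. Compound 2 therefore stands with compound 1 at the limit of > 64000 nM in this assay, at which 2 of the 2 values shown sit, and the two cannot be placed in any order.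

The next compound to be tested, compound 3 `CC1(COc2ccc(-c3ccc(OC(F)(F)F)cc3)cn2)CCn2cc([N+](=O)[O-])nc2O1`, is compound 2 with one small change: methyl in place of hydrogen on a saturated ring carbon. The methyl takes the place of a hydrogen on a saturated ring carbon, next to the ring oxygen. Within the data shown here, no pair of measured compounds shows what a single change does in this assay, so the expectation here is a cautious one. It rests only on the small size of the change and on the reading shared by compound 1 and compound 2, (the limit of > 64000 nM in this assay, at which 2 of the 2 values shown sit). The expected result is no change beyond the scatter, in either direction, with the estimated step being a number no higher from compound 2 to compound 3 (the limit leaves the size open). Compound 3 is expected to read close to the limit, and it may well be reported only as a limit. For compound 3 the estimated value is 64000 nM, with an expected range from 30000 nM to 128000 nM.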

Compound 3, half-maximal inhibitory concentration: > 64000 nM
Compound 3: only a limit was reported; the forecaster's own chance of this, stated with the estimate: 85%; the middle value lies on the limit itself.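

In this assay compound 3 gives > 64000 nM, which is a limit of the assay and not a number. Among these compounds, compound 2 also reads only as a limit, so no step between compound 2 and compound 3 can be read: the limit of > 64000 nM in this assay, at which 3 of the 3 values shown sit. The compounds shown leave open how far each lies beyond that limit, and whether the added methyl changes the reading at all.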